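Cyano in place of nitro: expected to stay inactive

The compounds below may be only part of what the source reports. "The series", "measured", "known", "first", "only" and "open" are said of these compounds alone.

Compound 1 `O=c1ccoc2cc(OCc3cn(Cc4ccccc4Cl)nn3)ccc12` and compound 2 `O=c1ccoc2cc(OCc3cn(Cc4ccc([N+](=O)[O-])cc4)nn3)ccc12` share the same core and differ only in the aryl group on the saturated chain carbon bound to an aromatic nitrogen. In a functional assay on A549 cells (Homo sapiens) for cytotoxicity, read by MTT assay, with a stated time of 48 h (a higher number here means a weaker inhibitor, a lower number a stronger inhibitor), compound 1 gives > 100000 nM, a limit of the assay rather than a number. In this assay compound 2 likewise gives > 100000 nM, again a limit and not a number. The step that the two limits leave unreadable from compound 1 to compound 2, 4-nitrophenyl in place of 2-chlorophenyl, therefore cannot be read in size, since both values sit at the limit of > 100000 nM in this assay, at which 2 of the 2 values shown sit. Among the compounds with values here, compound 2 thus stands at the limit, with no number to set it against the one other value shown, which is also a limit.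

Compound 3 `N#Cc1ccc(Cn2cc(COc3ccc4c(=O)ccoc4c3)nn2)cc1` is not yet measured. It differs from compound 2 by cyano in place of nitro on an aromatic carbon. Within the data shown here, the only measured step that bears on this change, a step that the two limits leave unreadable from compound 1 to compound 2, is unreadable and gives no direction. No step beyond the scatter is expected for compound 3, so the estimated step that the limit leaves unreadable from compound 2 to compound 3 amounts to essentially no change. Compound 3 is therefore estimated at 200000 nM in this assay, with a range from 50000 nM to 1000000 nM, most likely reported only as a limit.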

Compound 3, half-maximal inhibitory concentration: > 100000 nM
Compound 3: no number, only a limit; the forecaster's own chance of this, stated with the estimate: 85%; the middle value is on the limit's open side.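

Compound 3 gives > 100000 nM in this assay, a limit and not a number, so no step among compound 1, compound 2 and compound 3 can be read: the limit of > 100000 nM in this assay, at which 3 of the 3 values shown sit.

The compounds shown leave open how the 2-chlorophenyl, 4-nitrophenyl and 4-cyanophenyl groups rank against one another, and whether any aryl group on the shared core gives a readable number in this assay.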